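Adding a Methyl to the Core of Compound 1

The compounds below may be only part of what the source reports. "The series", "measured", "known", "first", "only" and "open" are said of these compounds alone.

Measured so far in a functional assay for inhibition, with Homo sapiens as the target; a higher number here means a weaker inhibitor, a lower number a stronger inhibitor:
Compound 1, `Cc1cc(C)cc(Nc2nccc(-c3cccnc3)n2)c1`, gives 800 nM.
Compound 2, `Cc1cc(-c2ccco2)nc(Nc2ccc(N(C)C)cc2)n1`, gives 5900 nM.
Compound 3, `CN(C)c1ccc(Nc2nccc(-c3ccco3)n2)cc1`, gives 1900 nM.

Compound 1 has the lowest of the three numbers. The difference between the cores of compound 1 and compound 3 is not broken down here. Compound 3 and compound 2 differ by one change, (methyl in place of hydrogen on an aromatic carbon), and that change gave a 3.1-fold higher number from compound 3 to compound 2 (0.49 log units; beyond the scatter).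

Compound 4, `Cc1cc(C)cc(Nc2ncc(C)c(-c3cccnc3)n2)c1`, is not yet measured. It differs from compound 1 by methyl in place of hydrogen on an aromatic carbon. This is the same kind of change as from compound 3 to compound 2, but the place differs: there the methyl sat next to the ring nitrogen and meta to a furan-2-yl group, here it sits ortho to a pyridin-3-yl group and two atoms from the ring nitrogen. Resting on a 3.1-fold higher number from compound 3 to compound 2 (0.49 log units; beyond the scatter), a weakening step of a 2.0-fold higher number from compound 1 to compound 4 (0.30 log units; within the scatter) is expected. The place is not the same, so the expected step is set smaller than that one. Compound 4 is estimated at 1600 nM in this assay, between 600 nM and 4500 nM.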

Compound 4, half-maximal inhibitory concentration: > 24000 nM
Compound 4 was reported as a limit; the forecaster's own chance of this, stated with the estimate: 3%; middle value at least 15-fold (1.17 log units) away from the limit.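

Compound 4 gives > 24000 nM in this assay, which is a limit of the assay and not a number. Methyl in place of hydrogen on an aromatic carbon gave an at least 30-fold higher number from compound 1 to compound 4 (1.47 log units; beyond the scatter), the same direction as on the other core, but the size of the step did not carry over: the same change on two cores in this assay, a 3.1-fold higher number (0.49 log units; beyond the scatter) from compound 3 to compound 2 and an at least 30-fold higher number (1.47 log units; beyond the scatter) from compound 1 to compound 4, at least 9.6-fold (0.98 log units) apart, beyond the scatter of two such steps. These two pairs differ in both the core and the place of the methyl, so they do not show which of the two sets the size of the step.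

The compounds shown leave open whether a methyl at this same place would act alike on the core of compound 3. They also leave open what an amine or a longer chain would do there on the core of compound 1.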